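The compounds below may be only part of what the source reports. "The series", "measured", "known", "first", "only" and "open" are said of these compounds alone.

Compound 2 `COc1ccc(C(=O)NC[C@H]2c3[nH]c4ccccc4c3C[C@H]3[C@H]4c5[nH]c6ccccc6c5C[C@@H]([C@H](C#N)N23)N4C)cc1` gives 430 nM in a functional assay on HCT-116 cells (Homo sapiens) for cytotoxicity, read by MTT assay, with a stated time of 72 h (a higher number here means a weaker inhibitor, a lower number a stronger inhibitor), the lowest of the three numbers measured. Compound 1 `CN1[C@@H]2c3[nH]c4ccccc4c3C[C@H]1[C@H](C#N)N1[C@@H](CNC(=O)c3cccc(C(F)(F)F)c3)c3[nH]c4ccccc4c3C[C@@H]21` gives 630 nM, and the step of a 1.5-fold lower number from compound 1 to compound 2 (0.17 log units; within the scatter) lies within the scatter. Among the compounds with values here, compound 3 `CN1[C@@H]2c3[nH]c4ccccc4c3C[C@H]1[C@H](C#N)N1[C@@H](CNC(=O)c3cccc4c3CCCC4)c3[nH]c4ccccc4c3C[C@@H]21` gives 4210 nM, so that a 9.8-fold higher number from compound 2 to compound 3 (0.99 log units; beyond the scatter) and a 6.7-fold higher number from compound 1 to compound 3 (0.82 log units; beyond the scatter) are the only steps beyond the scatter, both with the same amide-bearing core and the same kind of exchange of the aromatic group on the carbonyl carbon.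

Compound 4 `CN1[C@@H]2c3[nH]c4ccccc4c3C[C@H]1[C@H](C#N)N1[C@@H](CNC(=O)c3cc4ccccc4o3)c3[nH]c4ccccc4c3C[C@@H]21` differs from compound 2 only there: 1-benzofuran-2-yl in place of 4-methoxyphenyl on a carbonyl carbon

The step from compound 1 to compound 2 shows that swapping one six-membered aromatic group for another changed little, while the steps into compound 3 show that a larger bicyclic group on the carbonyl carbon gave a clearly higher number. The 1-benzofuran-2-yl group is also bicyclic, but wholly aromatic, so compound 4 is expected to sit between these cases, with a 2.1-fold higher number from compound 2 to compound 4 (0.32 log units; beyond the scatter) toward a higher number. The estimate for compound 4 is 900 nM, ranging from 300 nM to 3000 nM.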

Compound 4, half-maximal inhibitory concentration: 330 nM
For compound 4 the middle estimate is 2.7-fold (0.44 log units) above the measured one; the range from low to high includes it.
By their numbers in this assay, from the lowest: compounds 4, 2 and 1 (each within the scatter of the next); then compound 3.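

In this assay, a second fused ring on this carbonyl carbon does not in itself bring a higher number: with 1-benzofuran-2-yl, the result is a 1.3-fold lower number from compound 2 to compound 4 (0.11 log units; within the scatter) and a 1.9-fold lower number from compound 1 to compound 4 (0.28 log units; within the scatter), so compound 4 stays level with both single-ring compounds. The contrast with the other bicyclic group is clear, at a 13-fold lower number from compound 3 to compound 4 (1.11 log units; beyond the scatter), which leaves compound 3 as the only one of the four apart from the rest and shows that this position accepts a five-membered aromatic ring with an oxygen atom directly on the carbonyl carbon. Nothing available explains why the two bicyclic groups differ.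

Going by these compounds, whether an amine or a carboxylic acid on the aromatic group would keep the number at this level remains open. Also open, on these data alone, is whether a cyclohexyl group on the carbonyl carbon would give a number like that of compound 3.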